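Dimethylamino to methyl on two related cores

A few compounds are considered here, and "the series" means these few. Any claim that something is new, unique, unknown or untested is made for them only; others in the source may bear on it.

Measured so far:
compound 1 `Cc1ccc(/C=C2\S/C(=N\c3csc(-c4ccc(Cl)cc4)c3)NC2=O)cc1`: 1000 nM
compound 2 `CN(C)c1ccc(/C=C2\S/C(=N\c3csc(-c4ccc(Cl)cc4)c3)NC2=O)cc1`: 500 nM
compound 3 `CN(C)c1ccc(/C=C2\S/C(=N\c3nc(-c4ccc(Cl)cc4)cs3)NC2=O)cc1`: 200 nM

All three have been tested in a functional assay on HCT-116 cells (Homo sapiens) for cytotoxicity, read by MTT assay, with a stated time of 72 h; on this read-out lower numbers stand for stronger inhibition and higher numbers for weaker inhibition. Compound 1 gives 1000 nM, compound 2 gives 500 nM and compound 3 gives 200 nM; compound 3 has the lowest number, and its steps to compound 2 and to compound 1 are both beyond the scatter. The difference between the cores of compound 2 and compound 3 is not broken down here. Compound 2 and compound 1 differ in one place, (methyl in place of dimethylamino on an aromatic carbon), and that step reads a 2.0-fold higher number from compound 2 to compound 1 (0.30 log units; within the scatter). Compound 4 `Cc1ccc(/C=C2\S/C(=N\c3nc(-c4ccc(Cl)cc4)cs3)NC2=O)cc1` is not yet measured; it differs from compound 3 by the same change, (methyl in place of dimethylamino on an aromatic carbon). The expected step in this assay is of like size, a 2.0-fold higher number from compound 3 to compound 4 (0.30 log units; within the scatter), resting on the earlier step of a 2.0-fold higher number from compound 2 to compound 1 (0.30 log units; within the scatter). Compound 4 is estimated at 400 nM, with a range from 200 nM to 800 nM.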

Compound 4, half-maximal inhibitory concentration: 500 nM
Compound 4: middle estimate off by 1.3-fold (0.10 log units), on the low side, and the stated range covers the measured number.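

In this assay, methyl in place of dimethylamino on an aromatic carbon gives a 2.5-fold higher number from compound 3 to compound 4 (0.40 log units; beyond the scatter). Set beside the earlier step, the change reads alike on the two cores, with no difference between the steps that can be told apart: the same change on two cores in this assay, a 2.0-fold higher number (0.30 log units; within the scatter) from compound 2 to compound 1 and a 2.5-fold higher number (0.40 log units; beyond the scatter) from compound 3 to compound 4, 1.3-fold (0.10 log units) apart, within the scatter of two such steps. This supports carrying the change across these two cores in this one cell assay only; it does not show that the step would hold on any other core, and it gives no reason for the size of the step.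

Still open, going by these compounds, is whether methoxy, a carboxylic acid or a cyclic amine such as morpholine in the same place would read alike on both cores. Also open, on these data alone, is whether the step would hold in another assay.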